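Triazole substituent swap: ethoxycarbonyl to thiophene

The source may hold more compounds than are shown below. What is called first, only, known or untested is meant among the compounds shown, and "the series" means these compounds.

Measured so far:
Compound 1 `CCS[C@@H]1[C@H](SCC)[C@@H](Cn2cc(-c3ccc(OC)cc3)nn2)O[C@H]1n1ccc(=O)[nH]c1=O`: in a functional assay on HepG2 cells (Homo sapiens) for cytotoxicity, read by MTT assay, with a stated time of 72 h (a higher number here means that more compound is needed for the effect, a lower number that less compound is needed), compound 1 gives 16200 nM.
Compound 2 `CCS[C@@H]1[C@H](SCC)[C@@H](Cn2cc(-c3ccc(C)cc3)nn2)O[C@H]1n1ccc(=O)[nH]c1=O`: in this assay compound 2 gives 19900 nM.
Compound 3 `CCOC(=O)c1cn(C[C@H]2O[C@@H](n3ccc(=O)[nH]c3=O)[C@H](SCC)[C@@H]2SCC)nn1`: in this assay compound 3 gives >= 100000 nM, a limit of the assay rather than a number.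

Compound 3 thus stands at the limit of >= 100000 nM in this assay, at which 1 of the 3 values shown sits. Among the measured compounds shown here, the only measured step among the aryl-bearing analogues, a 1.2-fold higher number from compound 1 to compound 2 (0.09 log units; within the scatter), is flat. The steps into compound 3, an at least 6.1-fold higher number from compound 1 to compound 3 (0.79 log units; beyond the scatter) and an at least 5.0-fold higher number from compound 2 to compound 3 (0.70 log units; beyond the scatter), are both beyond the scatter. Compound 4 `CCS[C@@H]1[C@H](SCC)[C@@H](Cn2cc(-c3cccs3)nn2)O[C@H]1n1ccc(=O)[nH]c1=O` differs from compound 3 by thiophen-2-yl in place of ethoxycarbonyl on an aromatic carbon, reversing the direction of those steps. Because of an at least 6.1-fold higher number from compound 1 to compound 3 (0.79 log units; beyond the scatter) and an at least 5.0-fold higher number from compound 2 to compound 3 (0.70 log units; beyond the scatter), a lower number in this assay is expected for compound 4, as an at least 5.0-fold lower number from compound 3 to compound 4 (0.69 log units; beyond the scatter). Compound 4 is estimated at 20000 nM, with a range from 8000 nM to 60000 nM.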

Compound 4, half-maximal effective concentration: 91800 nM
Estimate against measurement, compound 4: 4.6-fold (0.66 log units) below; measured number above the stated range.
By their numbers in this assay, from the lowest: compounds 1 and 2 (each within the scatter of the next); then compound 4. At a limit, above all of these: compound 3.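

Swapping in an aromatic ring at this carbon does not by itself give numbers like those of compounds 1 and 2: thiophen-2-yl gives a 4.6-fold higher number from compound 2 to compound 4 (0.66 log units; beyond the scatter) and a 5.7-fold higher number from compound 1 to compound 4 (0.75 log units; beyond the scatter). Against ethoxycarbonyl, the change gives an at least 1.0-fold lower number from compound 3 to compound 4 (0.03 log units; that floor lies within the scatter), so no separation of the two groups can be claimed. Compound 3 remains a limit, not a number: the limit of >= 100000 nM in this assay, at which 1 of the 4 values shown sits.

Open, from the compounds shown here alone, is whether a plain phenyl, carrying neither methyl nor methoxy, would read with compounds 1 and 2 or with compound 4. Also open, going by these compounds, is how a pyridine ring or a carboxylic acid would read on this aromatic carbon.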